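The compounds below may be only part of what the source reports. "The series", "measured", "known", "first", "only" and "open" are said of these compounds alone.

Measured so far, in a physicochemical assay for solubility; a lower number here means a less soluble compound, a higher number a more soluble compound:

Compound 2, `NC(=O)c1ccccc1NC(=O)c1cc2cc([N+](=O)[O-])ccc2o1`, gives 5 ug/mL.
Compound 1, `COC(=O)c1ccc(NC(=O)c2cc3cc([N+](=O)[O-])ccc3o2)cc1`, gives 20 ug/mL.

Of these two numbers, compound 2 holds the lower one. Compound 1 sits higher, and the gap between compound 1 and compound 2 lies beyond the usual scatter of repeated measurements, so compound 2 is the less soluble of the pair.

The next compound, compound 3, `O=C(Nc1ccccc1)c1cc2cc([N+](=O)[O-])ccc2o1`, keeps the shared core and the anilide of compound 2 but drops one group: hydrogen in place of carbamoyl on an aromatic carbon. The ring that carried the carbamoyl is then plain.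

No measured pair among these compounds shows this same change, so there is no direct precedent for its size. What can be said is that compound 3 starts from a low point, because compound 2 gives only 5 ug/mL. A modest shift upward seems plausible, with a fall or no change beyond the scatter not ruled out.

The step from compound 2 to compound 3 is expected to be a 1.8-fold higher number from compound 2 to compound 3 (0.26 log units; within the scatter).

Compound 3 is estimated to give 9 ug/mL, within a range from 3 ug/mL to 27 ug/mL.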

Compound 3, solubility: 25 ug/mL
Beside the measured number, compound 3's estimate is 2.8-fold (0.44 log units) below it; measured number inside the range.
By their numbers in this assay, from the lowest: compound 2; then compounds 1 and 3 (each within the scatter of the next).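

In this assay, among the compounds shown here, swapping the carbamoyl for hydrogen on the aromatic carbon ortho to a large group gives a 5.0-fold higher number from compound 2 to compound 3 (0.70 log units; beyond the scatter), a step beyond the scatter and the first direct reading of what this group does at this position. Swapping the methoxycarbonyl for hydrogen on an aromatic carbon gives a 1.3-fold higher number from compound 1 to compound 3 (0.10 log units; within the scatter), which stays within the scatter, so the plain ring of compound 3 cannot be told apart from the ring carrying methoxycarbonyl, and of these two groups only carbamoyl marks a clear step from the plain ring. Nothing available here gives a measured reason for the gap between these two steps.

From the compounds shown here alone, what remains open is whether another group on that same aromatic carbon, such as a carboxylic acid, an amine or a fluorine atom, would leave the number close to that of the plain ring or pull it down as carbamoyl does. Going by these compounds, these steps also come from a single shared core, so whether swapping carbamoyl for hydrogen would give a step of similar size on any other core is unknown.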